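The source may report more compounds than this note shows. Statements on the series, on what has been measured and on what is new or still open speak of the compounds shown alone.

Working notes on the series. Compound 1 `Cc1ccc(Nc2ncc3c(n2)N(C)C(=O)N(c2cc(NC(=O)c4ccc(-n5cccc5)c(C(F)(F)F)c4)ccc2C)C3)cn1` is the reference point. For the measured compounds named here, in an ADME assay on BaF3 cells (Mus musculus) for inhibition, read by CellTiter-Glo, with a stated time of 72 h (on this read-out higher numbers stand for weaker inhibition of growth and lower numbers for stronger inhibition of growth), compound 1 gives 317 nM, the lowest number of the two measured so far. Compound 2 `Cc1ccc(NC(=O)c2cccc(C(F)(F)F)c2)cc1N1Cc2cnc(NC3CC3)nc2N(C)C1=O` differs from compound 1 in several places at once; in this assay compound 2 gives 5060 nM. Going by the values given here, the gap between these two values lies beyond the usual scatter, and since no single-point step connects them, the two numbers are taken simply as they stand.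

Compound 3 `Cc1ccc(Nc2ncc3c(n2)N(C)C(=O)N(c2cc(NC(=O)c4ccc(CN5CCC(N(C)C)C5)c(C(F)(F)F)c4)ccc2C)C3)cn1` has not yet been measured in this assay. It departs from compound 1 in one place: (3-(dimethylamino)pyrrolidin-1-yl)methyl in place of 1H-pyrrol-1-yl on an aromatic carbon. Among the compounds with values here, no measured pair in the set shows this change, so the expectation rests on compound 1 alone. Anchored on compound 1 at 317 nM, a small step toward a lower number is expected: a 2.0-fold lower number from compound 1 to compound 3 (0.30 log units; within the scatter). On that basis compound 3 is estimated to give about 160 nM in this assay, within a range of 40 nM to 600 nM.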

Compound 3, concentration for 50% growth inhibition: 636 nM
Beside the measured number, compound 3's estimate is 4.0-fold (0.60 log units) below it; the whole stated range lies below it.
By their numbers in this assay, from the lowest: compounds 1 and 3 (each within the scatter of the next); then compound 2.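

In this assay, for the compounds shown here, the exchange of 1H-pyrrol-1-yl for (3-(dimethylamino)pyrrolidin-1-yl)methyl gives a 2.0-fold higher number from compound 1 to compound 3 (0.30 log units; within the scatter), the first single-place step. At this aromatic carbon, ortho to a trifluoromethyl group and para to a large group, a five-membered aromatic ring of 5 heavy atoms and a five-membered non-aromatic ring group of 9 heavy atoms therefore cannot be told apart by this read-out. No measurement on hand accounts for this outcome.

Open, as far as these compounds go, is whether a carboxylic acid, a morpholine ring or a plain dimethylaminomethyl group at this carbon would give a step beyond the scatter. Also open, from the compounds shown here alone, is whether the same exchange would read alike on a core other than that of compound 1.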